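The source may report more compounds than this note shows. Statements on the series, on what has been measured and on what is new or still open speak of the compounds shown alone.

Measured so far in an assay on isolated protein for inhibition of prostaglandin E2 receptor EP1 subtype (Homo sapiens); on this read-out lower numbers stand for stronger inhibition and higher numbers for weaker inhibition:
compound 1 `O=C(O)c1cccc(C2=C(c3cc(Br)ccc3OCc3ccc(F)cc3)CCC2)c1`, 20 nM
compound 2 `CSc1ccc(OCc2ccc(F)cc2)c(C2=C(c3cccc(C(=O)O)c3)CCC2)c1`, 31.6 nM

Compound 1 gives the lowest of the two numbers; the nearest is compound 2, and the step of a 1.6-fold higher number from compound 1 to compound 2 (0.20 log units; within the scatter) lies within the scatter, so the two compounds are not separated by this assay. Compound 3 `O=C(O)c1ccnc(C2=C(c3cc(Br)ccc3OCc3ccc(F)cc3)CCC2)c1` has not yet been measured in this assay. Its change from compound 1 is 4-carboxypyridin-2-yl in place of 3-carboxyphenyl on a double-bonded ring carbon. For the measured compounds named here, no measured step bears on this change: the only known step, a 1.6-fold higher number from compound 1 to compound 2 (0.20 log units; within the scatter), alters a different part of the shared core and gives no information about the carboxy-bearing ring. With no guide from the data, the expected step is a 2.0-fold higher number from compound 1 to compound 3 (0.30 log units; within the scatter), leaning slightly toward a higher number and carrying a wide range. Compound 3 is therefore estimated at 40 nM, with a range from 10 nM to 160 nM.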

Compound 3, half-maximal inhibitory concentration: 3.16 nM
Compound 3: the middle estimate sits 13-fold (1.10 log units) above what was measured; measured number outside the range, below it.
By their numbers in this assay, from the lowest: compound 3; then compounds 1 and 2 (each within the scatter of the next).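

On the double-bonded ring carbon of the five-membered ring, 4-carboxypyridin-2-yl in place of 3-carboxyphenyl gives a 6.3-fold lower number from compound 1 to compound 3 (0.80 log units; beyond the scatter) in this assay, so this position moves the read-out, whereas the change elsewhere on the shared core, a 1.6-fold higher number from compound 1 to compound 2 (0.20 log units; within the scatter), left the two compounds unseparated. The entering group carries a ring nitrogen where the leaving group has carbon only, and it also has one more hydrogen-bond acceptor by the count, while its heavy-atom count stays the same. No supporting measurement accounts for the lower number of compound 3.

Still open, as far as these compounds go, is whether the step from this ring change carries over when methylsulfanyl stands in place of bromo. Also open, from the compounds shown here alone, is how the read-out responds when a tetrazole or a primary amide takes the place of the carboxylic acid on the 4-carboxypyridin-2-yl group.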